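This account rests on a few compounds, and the source may have more. Where it says the series, first, only, none or still open, it means among the compounds named here.

Of the compounds shown here, two sharing one core have been tested in a functional assay on MGC-803 cells (Homo sapiens) for antiproliferative activity, read by CCK-8 assay, with a stated time of 72 h, tested at 8 uM; on this read-out lower numbers stand for a weaker effect and higher numbers for a stronger effect at the one concentration tested. Compound 1 `Nc1ccccc1NC(=O)c1ccc(CSC(=S)N2CCN(c3ccccc3)CC2)cc1` gives 87.4% in this assay, while compound 2 `Nc1ccccc1NC(=O)c1ccc(CSC(=S)N2CCN(c3ncccn3)CC2)cc1` gives 64.8%. For the measured compounds named here, the one step measured between them, a number 22.6 percentage points lower from compound 1 to compound 2 (beyond the scatter), leaves compound 2 as the lowest of the two numbers, with compound 1 as its only neighbour. Compound 3 `Nc1ccccc1NC(=O)c1ccc(CSC(=S)N2CCN(C3CCCCC3)CC2)cc1` has not yet been measured. It differs from compound 2 in one place: cyclohexyl in place of pyrimidin-2-yl on an amine nitrogen in a ring. Going by the values given here, no measured step bears directly on this change; the only step in hand, a number 22.6 percentage points lower from compound 1 to compound 2 (beyond the scatter), exchanged one six-membered aromatic ring for another on the same ring nitrogen, and it was modest though beyond the scatter. That step shows the group on this ring nitrogen can move the read-out in this assay by a modest amount, but it gives no direction for a six-membered non-aromatic ring of carbon only. Compound 3 is therefore expected to show a step of a number 5.2 percentage points higher from compound 2 to compound 3 (within the scatter) that may well stay within the scatter. The estimate for compound 3 in this assay is 70%, expected to lie between 45% and 90%.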

Compound 3, a percentage reported as inhibition, at one concentration (the size of the read-out at that concentration, not a potency): 75.3%
Estimate against measurement, compound 3: 5.3 percentage points below; the measured number falls inside the stated range.
By their numbers in this assay, from the lowest: compound 2; then compound 3; then compound 1.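

The new compound shows that this position does not need an aromatic ring to hold a high number in this assay: a number a number 10.5 percentage points higher from compound 2 to compound 3 (beyond the scatter) shows that cyclohexyl, a six-membered non-aromatic ring of carbon only, reads above pyrimidin-2-yl on the same amine nitrogen in a ring. Aromaticity alone does not set the order among these three compounds, since the two aromatic groups, phenyl in compound 1 and pyrimidin-2-yl in compound 2, fall on either side of the non-aromatic cyclohexyl in compound 3. The other new step, a number 12.1 percentage points lower from compound 1 to compound 3 (beyond the scatter), shows that replacing phenyl with cyclohexyl also changes the read-out beyond the scatter, so the two carbon-only rings are not interchangeable here, and both stand above the ring with two nitrogens.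

Pyridin-2-yl, with a single ring nitrogen, or a small methyl or a longer chain such as n-butyl on this nitrogen would test how far these differences extend. The data shown offer no independent measurement that explains why the three groups fall in this order.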